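A few compounds are considered here, and "the series" means these few. Any claim that something is new, unique, unknown or untested is made for them only; others in the source may bear on it.

Within the data shown here, in a toxicity assay on HUVEC cells (Homo sapiens) for inhibition (on this read-out lower numbers stand for stronger inhibition of growth and higher numbers for weaker inhibition of growth), compound 2 `Cc1nc(-c2ccccc2)c(C(=O)N2CCN(c3ccccc3)CC2)o1` gives 9.63 ug/mL, the higher of the two numbers measured so far; compound 1 `COc1cc(OC)cc(N2CCN(C(=O)c3oc(C)nc3-c3cccc(F)c3)CC2)c1`, which differs from it in several places, gives 0.126 ug/mL, a gap well beyond the scatter. Compound 3 `Cc1nc(-c2ccccc2)c(C(=O)N2CCN(c3cc(Cl)cc(Cl)c3)CC2)o1` has not been measured. It differs from compound 2 by 3,5-dichlorophenyl in place of phenyl on an amine nitrogen in a ring. Among the measured compounds shown here, no measured pair isolates this change, so the expectation rests on the two values alone: the step expected in this assay is a 9.6-fold lower number from compound 2 to compound 3 (0.98 log units; beyond the scatter), toward stronger inhibition and beyond the scatter, yet smaller than the gap between compound 2 and compound 1. Compound 3 is therefore estimated at 1 ug/mL, within a range from 0.2 ug/mL to 5 ug/mL.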

Compound 3, concentration for 50% growth inhibition: 0.191 ug/mL
Compound 3: middle estimate off by 5.2-fold (0.72 log units), on the high side, and the stated range ends above it.
By their numbers in this assay, from the lowest: compounds 1 and 3 (each within the scatter of the next); then compound 2.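

In this assay, putting 3,5-dichlorophenyl in place of phenyl on an amine nitrogen in a ring gives a 50-fold lower number from compound 2 to compound 3 (1.70 log units; beyond the scatter) with the rest of the molecule unchanged. The earlier pair differed in several places, whereas this pair shows that this single change can strongly increase growth inhibition. No available evidence explains this step.

From the compounds shown here alone, it remains open whether one chlorine would give a similar step. Going by these compounds, the effect of a nitrile, an amine or a carboxylic acid on this phenyl ring also remains unknown.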